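The compounds below may be only part of what the source reports. "The series", "measured", "known", "first", "only" and "open" are said of these compounds alone.

In an assay on isolated protein for inhibition of cytosolic endo-beta-N-acetylglucosaminidase (Homo sapiens), tested at 1000 uM (a lower number here means less inhibition, a higher number more inhibition at the concentration tested (going by the name of the read-out)), compound 2, whose structure is `O=C(O)[C@H]1NC[C@H](O)[C@H](O)[C@@H]1O`, gives 26%. Among the three measured compounds this is the highest number. Compound 1, with the structure `O=C(O)[C@@H]1NCC=C[C@@H]1O`, gives 14% in this assay, and compound 3, with the structure `O=C(O)[C@H]1NC[C@H](O)[C@H](O)[C@H]1O`, gives 7.6%.

The step from compound 2 to compound 3 changes a single stereocentre and produces a number 18.4 percentage points lower from compound 2 to compound 3 (beyond the scatter), a drop that is real because of the fact that compounds 2 and 3 differ only in the configuration as drawn.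

Compound 4 has the structure `O=C(O)[C@H]1NC[C@H](O)[C@@H](O)[C@@H]1O`. It differs from compound 2 as follows: the two compounds have the same atoms and bonds and differ only in configuration as drawn: 1 of 4 stereo elements differ; a stereocentre at a saturated ring carbon is drawn S in compound 2 and R in compound 4. This is again a flip of one stereocentre at a saturated ring carbon, though a different one from the flip that led to compound 3. Among the measured compounds shown here, only the step from compound 2 to compound 3 bears on the question, and it shows that such a flip can lower the number by a modest but real amount. The same direction is therefore expected here, a step of roughly a number 13 percentage points lower from compound 2 to compound 4 (beyond the scatter), with wide uncertainty because a different centre is involved. Compound 4 is estimated to give 13% in this assay, with a plausible range from 3% to 27%.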

Compound 4, a percentage reported as inhibition, at one concentration (the size of the read-out at that concentration, not a potency): 43%
Beside the measured number, compound 4's estimate is 30 percentage points below it; the whole stated range lies below it.
By their numbers in this assay, from the lowest: compounds 3 and 1 (each within the scatter of the next); then compound 2; then compound 4.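

In this assay, flipping a single stereocentre at a saturated ring carbon can raise the number as well as lower it: where the earlier flip brought a drop, this one gives a number 17 percentage points higher from compound 2 to compound 4 (beyond the scatter). No atom enters or leaves, so this rise can rest only on the configuration as drawn: the fact that compounds 2 and 4 differ only in the configuration as drawn. With two stereocentres set differently, the record shows a number 35.4 percentage points higher from compound 3 to compound 4 (beyond the scatter), the largest step yet, so the configuration of these ring carbons matters in this series, and each centre has to be judged on its own.

The compounds shown leave open whether the other stereocentres respond in the same way. They also leave open whether a methyl ester or an amide in place of the carboxylic acid, or a longer chain on the ring nitrogen, would keep the number as high as it is for compound 4.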